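The compounds below may be only part of what the source reports. "The series", "measured", "known", "first", "only" and "open" are said of these compounds alone.

The compounds measured so far in a functional assay on B16-F10 cells (Mus musculus) for cytotoxicity, read by MTT assay, with a stated time of 48 h; a lower number here means a stronger inhibitor, a higher number a weaker inhibitor:

Compound 1, `O=C(/C=C\Nc1ccc(F)cc1)c1nc(-c2ccc(F)cc2)n2ccccc12`, gives > 30000 nM, which is a limit of the assay rather than a number.
Compound 2, `O=C(/C=C\Nc1cnc2ccccc2c1)c1nc(-c2ccccc2)n2ccccc12`, gives 3780 nM.
Compound 3, `O=C(/C=C\Nc1ccc2[nH]ccc2c1)c1nc(-c2ccc(C(F)(F)F)cc2)n2ccccc12`, gives 18200 nM.

Compound 1 therefore stands at the weak end of what has been seen: the limit of > 30000 nM in this assay, at which 1 of the 3 values shown sits. Compound 2 and compound 3 differ from compound 1 in more than one place, so their values show only where they lie on the scale, not what any single change does.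

Compound 4, `O=C(/C=C\Nc1ccc(Cl)cc1)c1nc(-c2ccc(F)cc2)n2ccccc12`, differs from compound 1 in one place: chloro in place of fluoro on an aromatic carbon. Among the compounds with values here, no pair of measured compounds isolates this change, so there is no measured step to lean on. Swapping one halogen for another at the same position is expected to shift the reading only a little, and the step from compound 1 to compound 4 is expected to be none beyond the scatter, a number no higher from compound 1 to compound 4 (the limit leaves the size open). Compound 4 is thus estimated at about 30000 nM, within a range of 12000 nM to 80000 nM, and it may well again return only a limit.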

Compound 4, half-maximal inhibitory concentration: 11000 nM
Estimate against measurement, compound 4: 2.7-fold (0.44 log units) above; the whole stated range lies above it.
By their numbers in this assay, from the lowest: compound 2; then compounds 4 and 3 (each within the scatter of the next). At a limit, above all of these: compound 1.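

In this assay, going from (4-fluorophenyl)amino to (4-chlorophenyl)amino gives an at least 2.7-fold lower number from compound 1 to compound 4 (0.43 log units; beyond the scatter), so this position responds to a single change of halogen by more than the scatter. Within the data shown here, this is the first step here that isolates one change, which the earlier compounds could not do as they differ in more than one place. Compound 1 stands at a limit, so the step has a lower bound but no known full size: the limit of > 30000 nM in this assay, at which 1 of the 4 values shown sits.

From the compounds shown here alone, what bromo, methoxy or an amine would do on the same aromatic carbon remains open, so one step cannot yet show a trend at this position. Also open, going by these compounds, is whether chloro in place of the other fluoro, on the second 4-fluorophenyl group of compound 4, would shift the reading in the same way.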